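Adding a Fluorine at a Second Place

The source may hold more compounds than are shown below. What is called first, only, known or untested is meant among the compounds shown, and "the series" means these compounds.

Compound 1 `Cc1ccc2nc(NC(=O)c3cn(-c4ccccc4)nc3-c3ccccc3)sc2c1` and compound 2 `Cc1ccc2nc(NC(=O)c3cn(-c4ccccc4)nc3-c3ccc(F)cc3)sc2c1` share one core. In a functional assay on A549 cells (Homo sapiens) for cytotoxicity, read by MTT assay, with a stated time of 72 h (on this read-out higher numbers stand for weaker inhibition and lower numbers for stronger inhibition), compound 1 gives 26500 nM and compound 2 gives 24600 nM. The change between them is fluoro in place of hydrogen on an aromatic carbon, and it made a 1.1-fold lower number from compound 1 to compound 2 (0.03 log units; within the scatter). Compound 3 `COc1ccc(-c2nn(-c3ccccc3)cc2C(=O)Nc2nc3ccccc3s2)cc1` has another core; how the two cores differ is not broken down here. In this assay compound 3 gives 13700 nM. Compound 4 `COc1ccc(-c2nn(-c3ccccc3)cc2C(=O)Nc2nc3ccc(F)cc3s2)cc1` is not yet measured and differs from compound 3 by fluoro in place of hydrogen on an aromatic carbon. This is the same kind of change as before, but the place differs: earlier the fluoro sat para to a large group, here it sits on a ring that is part of a fused or bridged system of two rings, meta to a fused ring and para to a fused ring. A similarly small step is expected, a 1.1-fold lower number from compound 3 to compound 4 (0.06 log units; within the scatter), because the earlier one was a 1.1-fold lower number from compound 1 to compound 2 (0.03 log units; within the scatter). Compound 4 is expected to give 12000 nM in this assay.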

Compound 4, half-maximal inhibitory concentration: 7560 nM
Compound 4: middle estimate off by 1.6-fold (0.20 log units), on the high side; the measured number falls inside the stated range.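

On the core of compound 3, the fluoro group gave a 1.8-fold lower number from compound 3 to compound 4 (0.26 log units; within the scatter) in this assay. Set beside the earlier step, the two do not differ by more than the usual scatter: the same change on two cores in this assay, a 1.1-fold lower number (0.03 log units; within the scatter) from compound 1 to compound 2 and a 1.8-fold lower number (0.26 log units; within the scatter) from compound 3 to compound 4, 1.7-fold (0.23 log units) apart, within the scatter of two such steps. These two pairs therefore show no sign that the change behaves differently from one core to the other, but the fluoro sits at a different place in each pair and neither step lies beyond the scatter, so they do not show that fluoro gives stronger inhibition on either core.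

The compounds shown leave open what other groups would do at the place of this fluoro, such as an amine or a carboxylic acid. Also open, going by these compounds, is how a fluoro at one place would compare with a fluoro at the other on a single core.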